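Methoxy on the anilino ring of a thiazolyl acetamide

A few compounds are considered here, and "the series" means these few. Any claim that something is new, unique, unknown or untested is made for them only; others in the source may bear on it.

Going by the values given here, compound 1 `Cc1nc(SCC(=O)Nc2nc(-c3ccc(Cl)cc3)cs2)n(Nc2ccccc2)c1C` is the only member of this small series with a numerical result in a functional assay on TK-10 cells (Homo sapiens) for antiproliferative activity, read by sulforhodamine B assay, with a stated time of 48 h; a lower number here means a stronger inhibitor of growth, a higher number a weaker inhibitor of growth: in this assay compound 1 gives 13800 nM, so it stands alone as the single point from which any expectation must start. Compound 2 `Cc1ccc(Nn2c(SCC(=O)Nc3nc(-c4ccccc4)cs3)nc(C)c2C)cc1` is the other measured member, and it reaches only a limit of the assay. In this assay compound 2 gives > 100000 nM, which is a limit and not a number; it is the same limit that the limit of > 100000 nM in this assay, at which 1 of the 2 values shown sits, describes. Among the compounds with values here, compound 2 differs from compound 1 in more than one place, so the two values show no single step.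

Compound 3 `COc1ccc(Nn2c(SCC(=O)Nc3nc(-c4ccc(Cl)cc4)cs3)nc(C)c2C)cc1` is not yet measured. It differs from compound 1 by methoxy in place of hydrogen on an aromatic carbon. Within the data shown here, with no measured step to lean on, the expected step from compound 1 to compound 3 is a 1.6-fold higher number from compound 1 to compound 3 (0.20 log units; within the scatter), which lies at the edge of the usual scatter. Compound 3 is therefore estimated at 22000 nM, with a range of 7000 nM to 80000 nM.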

Compound 3, concentration for total growth inhibition: 80900 nM
Compound 3: middle estimate off by 3.7-fold (0.57 log units), on the low side; the measured number lies above the stated range.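

Going by these compounds alone, the first single-place step falls on the anilino ring: phenyl to 4-methoxyphenyl, with methoxy para to a large group, gives a 5.9-fold higher number from compound 1 to compound 3 (0.77 log units; beyond the scatter) in this assay. A higher number here means a weaker inhibitor of growth, so this position does respond to substitution, and this change moves the result the wrong way, beyond the scatter. Compound 1 and compound 2 differ in more than one place and could not show this, and compound 2 remains a limit and not a number: the limit of > 100000 nM in this assay, at which 1 of the 3 values shown sits.

Within the data shown here, whether any added group at this carbon raises the number, or whether the step belongs to methoxy in particular, stays open, as only this one change can be read. A fluorine, a hydroxyl or an amine at the same place would separate those two readings, and a methoxy on another carbon of the same ring would show how far the step depends on where the group sits.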